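The compounds below may be only part of what the source reports. "The series", "measured", "known", "first", "only" and "open" are said of these compounds alone.

Working notes on the sulfamate series in an assay on HEK293 cells for inhibition of Steryl-sulfatase (Homo sapiens), tested at 1 uM; on this read-out higher numbers stand for a stronger effect at the one concentration tested and lower numbers for a weaker effect.

For the measured compounds named here, compound 2 `NS(=O)(=O)Oc1ccc2c(c1)CN(C(=O)c1cccc(N(Cc3ccccc3)Cc3ccco3)c1)CC2` gives 90.5% and stands second highest of the three numbers measured so far. Compound 3 `NS(=O)(=O)Oc1ccc2c(c1)CN(C(=O)c1ccc(N(Cc3ccccc3)Cc3ccco3)cc1)CC2` gives 98.2%, a number within the scatter of compound 2. Going by the values given here, compound 1 `CCN(Cc1ccccc1)c1cccc(C(=O)N2CCc3ccc(OS(N)(=O)=O)cc3C2)c1` gives 69%, and the step of a number 21.5 percentage points higher from compound 1 to compound 2 (beyond the scatter) is the only measured step that bears on the change considered next.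

Compound 4 `CN(C)CCCN(Cc1ccccc1)c1cccc(C(=O)N2CCc3ccc(OS(N)(=O)=O)cc3C2)c1` differs from compound 2 as follows: 2-(dimethylamino)ethyl in place of furan-2-yl on a saturated chain carbon bound to a nitrogen on an aromatic ring

Among the compounds with values here, the one bearing step shows that furan-2-yl in place of methyl on a saturated chain carbon bound to a nitrogen on an aromatic ring raised the number by a modest amount. Within the data shown here, in compound 4 the furan-2-yl leaves again and 2-(dimethylamino)ethyl enters at the same place; no measured compound carries this chain, so nothing is known of what it brings. On these data alone, only the loss of furan-2-yl has a precedent, and on that precedent a drop of modest size back toward the number of compound 1 is expected, with a wide range because the entering chain is untested. Compound 4 is therefore estimated at 75%, range 55% to 92%. The step this estimate means, a number 15.5 percentage points lower from compound 2 to compound 4 (beyond the scatter), is expected to lie beyond the scatter.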

Compound 4, a percentage reported as inhibition, at one concentration (the size of the read-out at that concentration, not a potency): 26%
Beside the measured number, compound 4's estimate is 49 percentage points above it, and the stated range ends above it.
By their numbers in this assay, from the lowest: compound 4; then compound 1; then compounds 2 and 3 (each within the scatter of the next).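

In this assay this place on a saturated chain carbon bound to a nitrogen on an aromatic ring can do more than give back the gain seen with furan-2-yl: the change to 2-(dimethylamino)ethyl gives (a number 64.5 percentage points lower from compound 2 to compound 4 (beyond the scatter)), and the result also falls well under that of the small ethyl-bearing compound, with (a number 43 percentage points lower from compound 1 to compound 4 (beyond the scatter)). The loss of furan-2-yl alone therefore does not cover the result, and the large step arises even though the leaving and entering groups have the same heavy-atom count and hydrogen-bond acceptor count, differing in the ring and in nitrogen for oxygen. Nothing available bears on what lies behind this fall.

The compounds shown leave open whether the fall goes with the terminal dimethylamino group or with the open chain itself, a question that a plain butyl chain at this place would address. Also open, on these data alone, is whether the high numbers need the furan-2-yl ring specifically or would hold with another ring such as cyclopentyl.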